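Changing the side chain end of compound 3

This account rests on a few compounds, and the source may have more. Where it says the series, first, only, none or still open, it means among the compounds named here.

In a functional assay on MDA-MB-468 cells (Homo sapiens) for antiproliferative activity, read by MTT assay, with a stated time of 48 h (on this read-out lower numbers stand for stronger inhibition and higher numbers for weaker inhibition), compound 1 `COc1cccc(C(=O)Nc2cc3cnc(NCCN(C)C)cc3n(C)c2=O)c1` gives 17400 nM and compound 2 `CN(C)CCNc1cc2c(cn1)cc(NC(=O)c1ccccc1)c(=O)n2C` gives 18300 nM, while compound 3 `CN(C)CCNc1cc2c(cn1)cc(NC(=O)c1cccc(-c3ccccc3)c1)c(=O)n2C` gives 1680 nM, the lowest of the three. Compound 4 `CCCNc1cc2c(cn1)cc(NC(=O)c1cccc(-c3ccccc3)c1)c(=O)n2C` differs from compound 3 in the side chain: methyl in place of dimethylamino on a saturated chain carbon, two bonds along the chain from a nitrogen on an aromatic ring. The measured steps are a 1.1-fold higher number from compound 1 to compound 2 (0.02 log units; within the scatter), an 11-fold lower number from compound 2 to compound 3 (1.04 log units; beyond the scatter) and a 10-fold lower number from compound 1 to compound 3 (1.02 log units; beyond the scatter). Each changes a group on an aromatic carbon, and none touches this chain, so they give no direct guide to its size. With no such evidence, no shift beyond the scatter is expected in this assay, though this is uncertain. The expected step is a 1.5-fold higher number from compound 3 to compound 4 (0.17 log units; within the scatter). Compound 4 is estimated at 2500 nM, with an expected range of 600 nM to 10000 nM.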

Compound 4, half-maximal inhibitory concentration: 1870 nM
Compound 4: middle estimate off by 1.3-fold (0.13 log units), on the high side; measured number inside the range.
By their numbers in this assay, from the lowest: compounds 3 and 4 (each within the scatter of the next); then compounds 1 and 2 (each within the scatter of the next).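

In this assay, propylamino in place of (2-(dimethylamino)ethyl)amino gives a 1.1-fold higher number from compound 3 to compound 4 (0.05 log units; within the scatter) and so leaves the number within the scatter. Among the compounds shown here, this is the first reading on the chain rather than on an aromatic carbon, and it shows that compound 3 can lose its dimethylamino group without a measurable shift in this assay. No measurement shown here explains this result.

The compounds shown leave open whether a longer chain, a carboxylic acid or a morpholine at this chain end would also leave the number unchanged.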